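A few compounds are considered here, and "the series" means these few. Any claim that something is new, unique, unknown or untested is made for them only; others in the source may bear on it.

Compound 1, `O=C(O)c1ccc(-c2cnc(C(=O)CCCCCCc3ccccc3)o2)cc1`: 60 nM
Compound 2, `O=C(CCCCCCc1ccccc1)c1ncc(C(=O)N2CCSCC2)o1`: 10 nM

Both numbers come from an assay (Rattus norvegicus) for inhibition of Fatty-acid amide hydrolase 1 (Homo sapiens); on this read-out higher numbers stand for weaker inhibition and lower numbers for stronger inhibition. Among the compounds with values here, compound 2 has the lower of the two numbers, and the only measured step, a 6.0-fold lower number from compound 1 to compound 2 (0.78 log units; beyond the scatter), separates it from compound 1. Compound 3, `O=C(CCCCCCc1ccccc1)c1ncc(Cl)o1`, differs from compound 2 in one place: chloro in place of (thiomorpholin-4-yl)carbonyl on an aromatic carbon. Within the data shown here, no measured step bears directly on this change; the one known step, a 6.0-fold lower number from compound 1 to compound 2 (0.78 log units; beyond the scatter), exchanged one large group for another of similar size, whereas here the large group gives way to a far smaller one, so the size of the effect is uncertain. Since compound 2 stands at 10 nM, compound 3 is expected to return a modestly higher number, an estimated step of a 4.0-fold higher number from compound 2 to compound 3 (0.60 log units; beyond the scatter). Compound 3 is therefore estimated at 40 nM in this assay, with a range from 10 nM to 160 nM.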

Compound 3, inhibition constant: 5 nM
Estimate against measurement, compound 3: 8.0-fold (0.90 log units) above, outside the stated range (below it).
By their numbers in this assay, from the lowest: compounds 3 and 2 (each within the scatter of the next); then compound 1.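

In this assay, within the data shown here, the aromatic carbon next to the ring oxygen accepts a far smaller group than the earlier compounds showed. The (thiomorpholin-4-yl)carbonyl, with its 8 heavy atoms, six-membered ring and 2 hydrogen-bond acceptors, gives way to a single chloro atom in a 2.0-fold lower number from compound 2 to compound 3 (0.30 log units; within the scatter), so the two compounds cannot be told apart. Neither that ring nor those acceptors are therefore required for a number at this level, while chloro in place of 4-carboxyphenyl gives a 12-fold lower number from compound 1 to compound 3 (1.08 log units; beyond the scatter), leaving compound 1 alone apart from the other two.

Nothing given here explains this tolerance. On these data alone, whether a hydrogen, a methyl or a nitrile on this carbon would keep the number at this level remains open, as does whether chloro would do so with a shorter chain in place of the phenyl-bearing chain.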